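The source may report more compounds than this note shows. Statements on the series, on what has been measured and on what is new or still open speak of the compounds shown alone.

Measured so far in a functional assay on MCF7 cells (Homo sapiens) for inhibition, read by MTT assay, with a stated time of 72 h; a lower number here means a stronger inhibitor of growth, a higher number a weaker inhibitor of growth:
Compound 1 `N#C/C(=C\c1c(F)c(F)c(F)c(F)c1F)C(=O)c1ccc[nH]1` gives 23000 nM.
Compound 2 `N#C/C(=C\c1c(F)c(F)c(F)c(F)c1F)C(=O)c1c[nH]c2ccccc12` gives 13000 nM.
Compound 3 `COc1ccc(CNC(=O)/C(C#N)=C/c2ccco2)cc1` gives 27000 nM.

Compound 3 carries the highest of the three numbers, but its gap to compound 1 lies within the usual scatter, so the two cannot be ranked against each other; its gap to compound 2 lies beyond the scatter, so compound 2 is the only one of the three that separates from compound 3 in this assay. Within the data shown here, no step between measured compounds that differ in one place is available, so nothing in the set itself calibrates a single substitution.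

Compound 4 `COc1ccc(CNC(=O)/C(C#N)=C/c2ccc(Br)o2)cc1` has not yet been measured. It differs from compound 3 by bromo in place of hydrogen on an aromatic carbon, next to the ring oxygen, two ring bonds from the ring atom that bears a large group. Among the measured compounds shown here, with no comparable step, the expectation rests on the change alone: a modest lowering of the number in this assay, small enough that it may not clear the scatter. Compound 4 is expected to give 15000 nM, within 6000 nM to 40000 nM, which corresponds to an estimated step of a 1.8-fold lower number from compound 3 to compound 4 (0.26 log units; within the scatter).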

Compound 4, concentration for 50% growth inhibition: 11000 nM
Compound 4: middle estimate off by 1.4-fold (0.13 log units), on the high side; measured number inside the range.
By their numbers in this assay, from the lowest: compounds 4, 2, 1 and 3 (each within the scatter of the next, the first and the last beyond it).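

In this assay, among these compounds, bromo in place of hydrogen on an aromatic carbon of the five-membered aromatic ring with 1 oxygen, next to the ring oxygen, gives a 2.5-fold lower number from compound 3 to compound 4 (0.39 log units; beyond the scatter) and is the first step that isolates one change. The furan-2-yl to 5-bromofuran-2-yl change thus shows that this position accepts a bromine atom with a modest lowering of the number, and it gives the series its first calibrated single substitution. No supporting data link the step to any property of the bromo group, so its origin remains unassigned.

A single substituent at a single position leaves open whether the lower number is specific to bromo, and chloro, methyl, an amine or a carboxylic acid at the same place would show whether other groups follow it or depart from it. Also open, as far as these compounds go, is whether the same change would produce a step of similar size on a core other than that of compound 3.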